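Removing One Chloro Substituent From Compound 2

The source may report more compounds than this note shows. Statements on the series, on what has been measured and on what is new or still open speak of the compounds shown alone.

Three compounds were tested in a functional assay on DU-145 cells (Homo sapiens) for cytotoxicity, read by MTT assay; on this read-out lower numbers stand for stronger inhibition and higher numbers for weaker inhibition. Compound 1 `CC(O)(CS(=O)(=O)c1ccccc1)c1nc(-c2ccccc2)no1` gives > 100000 nM, which is a limit of the assay rather than a number. Compound 2 `CC(O)(CS(=O)(=O)c1ccc(Cl)cc1)c1nc(-c2ccc(Cl)cc2)no1` gives > 100000 nM, again only a limit. Compound 3 `CC(O)(CSc1ccc(Br)cc1)c1nc(-c2ccccc2)no1` gives > 100000 nM, also a limit. Compound 2 therefore stands at the limit of > 100000 nM in this assay, at which 3 of the 3 values shown sit, and all three compounds rest there, so no ordering among them can be drawn. Compound 4 `CC(O)(CS(=O)(=O)c1ccccc1)c1nc(-c2ccc(Cl)cc2)no1` differs from compound 2 by one change: hydrogen in place of chloro on an aromatic carbon, para to a large group, so that one 4-chlorophenyl becomes a phenyl. Going by the values given here, no pair of measured compounds shares this exact change, so no measured step guides the expectation. Because all three values sit at the limit of > 100000 nM in this assay, at which 3 of the 3 values shown sit, the expectation is that compound 4 also reports only the limit, with no shift beyond the scatter in this assay. Compound 4 is accordingly estimated at 150000 nM, with a range from 30000 nM to 1000000 nM, which for the step from compound 2 to compound 4 means an expected step that the limit leaves unreadable from compound 2 to compound 4.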

Compound 4, half-maximal inhibitory concentration: > 100000 nM
Compound 4 ended at the assay's limit; the forecaster's own chance of this, stated with the estimate: 85%; the middle value lies beyond the limit too.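

No step can be read from compound 2 to compound 4, or from compound 1 to compound 4, because all the compounds rest at one limit in this assay: the limit of > 100000 nM in this assay, at which 4 of the 4 values shown sit.

The compounds shown leave open whether swapping chloro for hydrogen changes activity at all.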